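Glycine-to-alanine and valine-to-leucine swaps in an inert series

The source may hold more compounds than are shown below. What is called first, only, known or untested is meant among the compounds shown, and "the series" means these compounds.

Three members of the series share one indole-based core and differ only in the dipeptide tail. Compound 1 `CC(C)[C@H](NC(=O)CNC(=O)c1cn(CC(=O)NOCc2ccccc2)c2ccccc12)C(=O)O` carries the glycine-valine tail; in a functional assay on RAW264.7 cells (Mus musculus) for inhibition, read by microscopy and resazurin assay, with a stated time of 72 h (a lower number here means a stronger inhibitor, a higher number a weaker inhibitor), compound 1 gives > 128000 nM, which is a limit of the assay and not a number. Compound 2 `CC(C)C[C@H](NC(=O)CNC(=O)c1cn(CC(=O)NOCc2ccccc2)c2ccccc12)C(=O)O` differs by isobutyl in place of isopropyl on a saturated chain carbon bound to an amide-type nitrogen and a carbonyl carbon; in this assay compound 2 gives > 128000 nM, again a limit. Compound 3 `CC(C)[C@H](NC(=O)[C@H](C)NC(=O)c1cn(CC(=O)NOCc2ccccc2)c2ccccc12)C(=O)O` differs from compound 1 by methyl in place of hydrogen on a saturated chain carbon bound to an amide-type nitrogen and a carbonyl carbon, and in this assay compound 3 gives > 128000 nM, also a limit. Accordingly the measured steps are a step that the two limits leave unreadable from compound 1 to compound 2, a step that the two limits leave unreadable from compound 1 to compound 3 and a step that the two limits leave unreadable from compound 2 to compound 3; all three values rest at the limit of > 128000 nM in this assay, at which 3 of the 3 values shown sit.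

Compound 4 `CC(C)C[C@H](NC(=O)[C@H](C)NC(=O)c1cn(CC(=O)NOCc2ccccc2)c2ccccc12)C(=O)O` is the unmeasured member; it differs from compound 3 by isobutyl in place of isopropyl on a saturated chain carbon bound to an amide-type nitrogen and a carbonyl carbon, the same change as that from compound 1 to compound 2, made on the same place. Since that change left compound 2 at its limit, and compound 3 itself sits at the limit, no recovery of inhibition is expected; the expected step is a step that the limit leaves unreadable from compound 3 to compound 4, set beside a step that the two limits leave unreadable from compound 1 to compound 2. Compound 4 is therefore estimated at 200000 nM, with a range from 100000 nM to 1000000 nM, most probably reported only as a limit.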

Compound 4, half-maximal inhibitory concentration: > 128000 nM
Compound 4: a limit, no number (the forecaster's own chance of this, stated with the estimate: 85%); the middle value does not contradict the limit.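

In this assay compound 4 gives > 128000 nM, a limit and not a number. The steps to compound 4 from compound 2 and compound 3 therefore cannot be read, as every value rests at one limit: the limit of > 128000 nM in this assay, at which 4 of the 4 values shown sit.

The compounds shown leave open how these four dipeptide tails differ in inhibition, and whether any tail on the shared core gives a readable value.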